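Replacing a pyrazole with a fused bicyclic group on the amide chain

The source may hold more compounds than are shown below. What is called first, only, known or untested is meant among the compounds shown, and "the series" means these compounds.

Two compounds from this series have been run in an ADME assay on microsomes from liver (Homo sapiens) for metabolic stability, read by LC-MS, using NADPH, with a stated time of 15 min, tested at 1 uM; a higher number here means faster removal of the compound, a lower number slower removal. Compound 1 `C[C@@H]1CN(c2sc(C(F)(F)F)nc2-c2nc3cc(OCCO)ccc3[nH]2)CCN1C(=O)Cn1cnc2cccnc21` gives 43 mL.min-1.g-1 in this assay. Compound 2 `C[C@@H]1CN(c2sc(C(F)(F)F)nc2-c2nc3ccccc3[nH]2)CCN1C(=O)Cn1cccn1` gives 44 mL.min-1.g-1 in this assay. Among the measured compounds shown here, the two numbers sit within the usual scatter of each other, so compound 2 cannot be placed above or below compound 1 on this read-out; the two compounds share one core and differ in more than one place, so no single step between them can be drawn.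

Compound 3 `C[C@@H]1CN(c2sc(C(F)(F)F)nc2-c2nc3ccccc3[nH]2)CCN1C(=O)Cn1cnc2c1CCN(C)C2` has not yet been measured. It keeps everything of compound 2 except for one change: a group of 10 heavy atoms (7 carbon, 3 nitrogen; one five-membered aromatic ring with 2 hetero atoms, one six-membered non-aromatic ring with 1 hetero atom) in place of a group of 5 heavy atoms (3 carbon, 2 nitrogen; one five-membered aromatic ring with 2 hetero atoms), on a saturated chain carbon bound to a carbonyl carbon

For the measured compounds named here, no measured pair in this set isolates a change of this kind, so the expectation for compound 3 rests on compound 2 alone and on the size of the group that enters. A modest move toward faster removal in this assay is expected, though a result within the scatter of compound 2 would not surprise. The expected step from compound 2 to compound 3 is a 1.5-fold higher number from compound 2 to compound 3 (0.17 log units; within the scatter). Compound 3 is estimated at 65 mL.min-1.g-1 in this assay, with a likely range from 28 mL.min-1.g-1 to 150 mL.min-1.g-1.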

Compound 3, intrinsic clearance in microsomes in the Homo sapiens assay: 21 mL.min-1.g-1
Estimate against measurement, compound 3: 3.1-fold (0.49 log units) above; the whole stated range lies above it.
By their numbers in the Homo sapiens assay, from the lowest: compound 3; then compounds 1 and 2 (each within the scatter of the next).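

Among the compounds shown here, this is the first reading of a single change at this place: with 1H-pyrazol-1-yl swapped for the larger group with its added six-membered non-aromatic ring, on a saturated chain carbon bound to a carbonyl carbon, the Homo sapiens assay shows a 2.1-fold lower number from compound 2 to compound 3 (0.32 log units; beyond the scatter) in a direction that favours slower removal. In a physicochemical assay for solubility, in simulated intestinal fluid (a higher number here means a more soluble compound, a lower number a less soluble compound), compound 2 gives 352 ug/mL and the same change brings an at least 2.6-fold higher number from compound 2 to compound 3 (0.41 log units; beyond the scatter) as well, so the larger group at this place comes with better numbers on both read-outs for this one pair. In the physicochemical assay compound 3 gives > 920 ug/mL and this is a limit of the assay, not a number.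

One pair cannot tell whether the added ring itself or its methyl-bearing ring nitrogen goes with these steps, and a simple amine, a morpholine ring or a carboxylic acid on the same chain carbon would test that. Nothing shown gives a cause for either step.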